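Flipping One Ring Stereocentre in a Weak Inhibitor Pair

The source may report more compounds than this note shows. Statements on the series, on what has been measured and on what is new or still open speak of the compounds shown alone.

Two measured compounds share one core and a saturated ring. Compound 1 `CSc1nc2sncc2n1[C@H]1C[C@H](O)[C@@H](CO)O1` gives 15000 nM in a functional assay on HFF cells (Homo sapiens) for inhibition; a higher number here means a weaker inhibitor, a lower number a stronger inhibitor. Compound 2 `CSc1nc2sncc2n1[C@@H]1O[C@H](CO)[C@@H](O)[C@@H]1O` gives 21000 nM in this assay. Among these two numbers compound 2 has the highest, and the only measured step is a 1.4-fold higher number from compound 1 to compound 2 (0.15 log units; within the scatter), so the two values cannot be told apart.

Compound 3 `CSc1nc2sncc2n1[C@@H]1O[C@H](CO)[C@@H](O)[C@H]1O` is not yet measured in this assay. How compound 3 differs from compound 2: the two compounds have the same atoms and bonds and differ only in configuration as drawn: 1 of 4 stereo elements differ; a stereocentre at a saturated ring carbon is drawn S in compound 2 and R in compound 3. Among the compounds with values here, no measured step changes only a configuration, so none bears directly on this change; the one available step, a 1.4-fold higher number from compound 1 to compound 2 (0.15 log units; within the scatter), shows a change on the saturated ring that stayed within the scatter. Compound 3 is therefore expected to give about 21000 nM in this assay, between 7000 nM and 63000 nM. This corresponds to an expected no change at the digits printed from compound 2 to compound 3 (within the scatter).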

Compound 3, half-maximal inhibitory concentration: 21000 nM
Beside the measured number, compound 3's estimate shows no gap at the digits printed; the range from low to high includes it.
By their numbers in this assay, from the lowest: compounds 1, 2 and 3 (each within the scatter of the next).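

Flipping this one stereocentre from S to R gives no change at the digits printed from compound 2 to compound 3 (within the scatter) in this assay, the first measured step that changes only a configuration, so at this saturated ring carbon the configuration as drawn makes no detectable difference. Placing the hydroxy on the saturated ring carbon gives a 1.4-fold higher number from compound 1 to compound 3 (0.15 log units; within the scatter), the same size as a 1.4-fold higher number from compound 1 to compound 2 (0.15 log units; within the scatter), so either configuration of the hydroxy leaves the step within the scatter. This pair isolates a single stereocentre: the fact that compounds 2 and 3 differ only in the configuration as drawn

On these data alone, whether an amine or a fluorine atom on this ring carbon, in place of the hydroxy, would move the number beyond the scatter remains open. As far as these compounds go, the effect of flipping any of the other stereocentres on the ring also remains open.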